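A few compounds are considered here, and "the series" means these few. Any claim that something is new, unique, unknown or untested is made for them only; others in the source may bear on it.

Measured so far:
Compound 1, `CC(C)c1ccc(/C=C/C(=O)OCCc2ccccc2)cc1`: 36%
Compound 2, `CC(C)c1ccc(/C=C/C(=O)OCCOc2ccccc2)cc1`: 32%

In a functional assay on the whole organism for inhibition, with Brassica rapa subsp. chinensis as the target, with a stated time of 3 days, tested at 100 ppm (on this read-out lower numbers stand for less inhibition of growth and higher numbers for more inhibition of growth at the one concentration tested), compound 2 gives 32%, and compound 1 gives 36%; the two numbers lie within the scatter of each other, so neither can be called the stronger inhibitor. Compound 3, `CCCCCOC(=O)/C=C/c1ccc(C(C)C)cc1`, differs from compound 2 in one place: propyl in place of phenoxy on a saturated chain carbon, two bonds along the chain from an oxygen next to a carbonyl group. For the measured compounds named here, only one measured step touches this part of the molecule: the change from phenyl to phenoxy at the same chain carbon, which gave a number 4 percentage points lower from compound 1 to compound 2 (within the scatter). That step swapped one aromatic group for another, whereas the new step removes the ring altogether and leaves a short chain, so it is not a close match. With only a step within the scatter to go on, no shift beyond the scatter is expected in this assay, and the range is kept wide. The expected step is a number 1 percentage points higher from compound 2 to compound 3 (within the scatter). Compound 3 is therefore estimated at 33%, between 12% and 58%.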

Compound 3, percent growth inhibition at one concentration: 29%
Estimate against measurement, compound 3: 4 percentage points above; the range from low to high includes it.
By their numbers in this assay, from the lowest: compounds 3, 2 and 1 (each within the scatter of the next).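

Measured by this assay this chain carbon now carries a group with no ring at all, and the result barely registers. Propyl in place of phenoxy gives a number 3 percentage points lower from compound 2 to compound 3 (within the scatter) and propyl in place of phenyl gives a number 7 percentage points lower from compound 1 to compound 3 (within the scatter) so among these three compounds an aromatic ring at this place is not needed to keep the number at this level, which the earlier swap of one ring-bearing group for another could not show. No measurement is available that would explain why the three compounds read alike.

Going by these compounds, it remains open whether any group on this chain carbon can move the number beyond the scatter, for instance an amine, a carboxylic acid or a longer chain. The compounds shown also leave open whether this lack of a readable difference would hold at other concentrations.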